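Bromo to vinyl in a cytotoxicity series

This account rests on a few compounds, and the source may have more. Where it says the series, first, only, none or still open, it means among the compounds named here.

In an ADME assay on MT4 cells (Homo sapiens) for cytotoxicity, read by XTT assay, with a stated time of 5 days (a higher number here means that more compound is tolerated, a lower number that less compound is tolerated), compound 1 (`C=CCNC(=O)[C@@H](NC(=O)[C@@](O)(CCCN(Cc1ccc(Br)cc1)NC(=O)[C@@H](NC(=O)OC)C(C)(C)C)Cc1ccc(Br)cc1)C(C)C`) gives 22000 nM as its reading. Compound 2 (`C=CCNC(=O)[C@@H](NC(=O)[C@](O)(CCCN(Cc1ccc(Br)cc1)NC(=O)[C@@H](NC(=O)OC)C(C)(C)C)Cc1ccc(Br)cc1)C(C)C`) gives 4500 nM and compound 3 (`C=CCNC(=O)[C@@H](NC(=O)[C@@](O)(CCCN(Cc1ccc(Br)cc1)NC(=O)[C@@H](NC(=O)OC)C(C)(C)C)Cc1ccc(Br)cc1)C(C)(C)C`) gives 29000 nM under the same conditions. Compound 1 thus sits in the upper part of these three numbers. A methyl in place of hydrogen brings a 1.3-fold higher number from compound 1 to compound 3 (0.12 log units; within the scatter) and so no real change, while the inverted stereocentre brings a 4.9-fold lower number from compound 1 to compound 2 (0.69 log units; beyond the scatter) as a real drop. That drop comes with the fact that compounds 1 and 2 differ only in the configuration as drawn and nothing else.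

Compound 4 (`C=CCNC(=O)[C@@H](NC(=O)[C@@](O)(CCCN(Cc1ccc(Br)cc1)NC(=O)[C@@H](NC(=O)OC)C(C)(C)C)Cc1ccc(C=C)cc1)C(C)C`) differs from compound 1 by vinyl in place of bromo on an aromatic carbon in one place, vinyl in place of bromo on an aromatic carbon, with 4-bromobenzyl becoming 4-vinylbenzyl. Neither measured step touches that group, so they offer only a rough sense of how far this assay moves in this series. No step beyond the scatter is expected in either direction. The expected move is a 1.2-fold lower number from compound 1 to compound 4 (0.09 log units; within the scatter) at the estimate. Compound 4 is therefore expected at 18000 nM with an estimated range of 7000 nM to 40000 nM in this read-out.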

Compound 4, half-maximal cytotoxic concentration: 25000 nM
Estimate against measurement, compound 4: 1.4-fold (0.14 log units) below, and the stated range covers the measured number.
By their numbers in this assay, from the lowest: compound 2; then compounds 1, 4 and 3 (each within the scatter of the next).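

In this assay, putting vinyl in place of bromo at one of the two 4-bromobenzyl groups gives a 1.1-fold higher number from compound 1 to compound 4 (0.06 log units; within the scatter). Going by these compounds alone, this is the first reading at this position, which neither earlier step touched, and it shows that 4-vinylbenzyl can stand where 4-bromobenzyl stood without a real move in the tolerated concentration. The facts at hand concern only configuration and offer no explanation for this result.

On these data alone, it remains open whether the same exchange would read alike at the other 4-bromobenzyl group, or on the background of compound 2 or compound 3. As far as these compounds go, it is also open how this position would respond to a group of a different kind, such as an amine or a carboxylic acid.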